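Microsomal stability across a small amide series

The source may report more compounds than this note shows. Statements on the series, on what has been measured and on what is new or still open speak of the compounds shown alone.

Compound 1 `Cc1cccc2cc([C@H](C)Nc3ncnc4[nH]cnc34)c(-c3ccccc3)c(=O)n12` gives 73%
Compound 2 `Cc1ccc2cc([C@H](C)Nc3ncnc4[nH]cnc34)c(-c3ccccc3)c(=O)n2c1` gives "not determined" (no result reported)
Compound 3 `C[C@H](Nc1ncnc2[nH]cnc12)c1cc2ccc(F)cn2c(=O)c1-c1ccccc1` gives 95%

Notes on the series in an ADME assay on microsomes from liver (Rattus norvegicus), read by LC-MS, using NADPH, with a stated time of 30 min, tested at 1 uM; on this read-out lower numbers stand for a less stable compound and higher numbers for a more stable compound. Two numbers are known. Compound 3 gives 95% and stands highest of the two; compound 1 gives 73%, a number lower than that of compound 3 by a gap beyond the usual scatter. Compound 2 has no result in this assay and contributes nothing to the comparison. For the measured compounds named here, no pair of measured compounds differs in a single place, so no single-change step is available from the measured set.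

Compound 4 `C[C@H](Nc1nc(N)ncc1C#N)c1cc2ccc(F)cn2c(=O)c1-c1ccccc1` is not yet measured. It differs from compound 3 in one place: a group of 9 heavy atoms (5 carbon, 4 nitrogen; one six-membered aromatic ring with 2 hetero atoms) in place of a group of 9 heavy atoms (5 carbon, 4 nitrogen; one five-membered aromatic ring with 2 hetero atoms, one six-membered aromatic ring with 2 hetero atoms), on an amine nitrogen. The shared core, with the amide and the chain carbon bearing the amine, is unchanged.

Going by the values given here, with no matching step among the measured compounds, the size of the change cannot be read from the data. Compound 3 is already near the top of the read-out, so a small downward step is expected, of a size that may still fall within the scatter. Compound 4 is estimated at 80%, with a range from 55% to 98%. This estimate means an expected step of a number 15 percentage points lower from compound 3 to compound 4 (beyond the scatter).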

Compound 4, percent of the compound remaining: 74%
Compound 4: middle estimate off by 6 percentage points, on the high side, within the range that was stated.
By their numbers in this assay, from the lowest: compounds 1 and 4 (each within the scatter of the next); then compound 3.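

This gives the series its first single-place step: in this assay, the change on the amine nitrogen is a number 21 percentage points lower from compound 3 to compound 4 (beyond the scatter), a modest step, with 2-amino-5-cyanopyrimidin-4-yl as the entering group. The shared core stays the same and the two compounds hold the same atoms, joined differently, so this position responds to how those atoms are arranged and not only to which atoms are present. No accompanying measurement bears on the result, and the step therefore stands without an assigned cause.

The compounds shown do not separate the contributions of the amino group, the nitrile and the replacement of the two-ring group by a single ring, so a pyrimidine carrying only the amino group, or a chlorine or a carboxamide in place of the nitrile, would be needed to tell these apart. From the compounds shown here alone, it also remains open whether the same exchange on the amine nitrogen gives a step of similar size on the core of compound 1, which has a methyl group in place of the fluorine.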